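The compounds below may be only part of what the source reports. "The series", "measured", "known", "first", "only" and "open" are said of these compounds alone.

Values so far in a physicochemical assay for solubility, read by spectrophotometry, in phosphate buffer, with a stated time of 18 h, at pH 7.4; on this read-out lower numbers stand for lower solubility and higher numbers for higher solubility:

compound 1 `CCc1ccc(-c2nc3c(c(C)nn3-c3ccccc3)c(-c3ccccc3I)c2C#N)cc1` gives 8500 nM
compound 2 `CCc1ccc(-c2nc3c(c(C)nn3-c3ccccc3)c(-c3ccccc3Br)c2C#N)cc1` gives 1500 nM
compound 3 `CCc1ccc(-c2nc3c(c(C)nn3-c3ccccc3)c(-c3ccccc3F)c2C#N)cc1` gives 1700 nM

Compound 1 alone holds the top of this short series: a 5.7-fold lower number from compound 1 to compound 2 (0.75 log units; beyond the scatter) and a 5.0-fold lower number from compound 1 to compound 3 (0.70 log units; beyond the scatter) are both beyond the scatter. By contrast, a 1.1-fold higher number from compound 2 to compound 3 (0.05 log units; within the scatter) is within it. Among the measured compounds shown here, compound 3 therefore stands in the lower pair of the three numbers, with no order inside that pair.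

The next step leads to compound 4 `CCc1ccc(-c2nc3c(c(C)nn3-c3ccccc3)c(-c3ccccc3)c2C#N)cc1` and is hydrogen in place of fluoro on an aromatic carbon, or 2-fluorophenyl to phenyl. For the measured compounds named here, no measured step has hydrogen entering, so the evidence is indirect. The closest exchange is fluoro in place of bromo, a 1.1-fold higher number from compound 2 to compound 3 (0.05 log units; within the scatter), while the two larger steps both start from compound 1. No shift beyond the scatter is expected in this assay. The expected change is a 1.2-fold higher number from compound 3 to compound 4 (0.07 log units; within the scatter), and its direction is uncertain. Compound 4 is estimated at 2000 nM, with an expected range from 800 nM to 5000 nM.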

Compound 4, solubility: 47000 nM
Compound 4: middle estimate off by 24-fold (1.37 log units), on the low side; measured number above the stated range.
By their numbers in this assay, from the lowest: compounds 2 and 3 (each within the scatter of the next); then compound 1; then compound 4.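

In this assay, this position responds most to losing the halogen altogether, not to exchanging one halogen for another: a 28-fold higher number from compound 3 to compound 4 (1.44 log units; beyond the scatter) and a 31-fold higher number from compound 2 to compound 4 (1.50 log units; beyond the scatter), whereas a 1.1-fold higher number from compound 2 to compound 3 (0.05 log units; within the scatter). Iodo also gives way to hydrogen, with a 5.5-fold higher number from compound 1 to compound 4 (0.74 log units; beyond the scatter), so compound 4, with hydrogen on this aromatic carbon, holds the top of the four numbers and the three halogens all lie beyond the scatter below it. What lies behind this jump is not explained by any measurement in hand.

As far as these compounds go, whether a non-halogen group at this position, such as methoxy or an amine, stays near the number of compound 4 or falls back towards the halogen compounds remains open. Also open, from the compounds shown here alone, is whether hydrogen in place of fluoro gives a shift of similar size on a version of the shared core carrying a carboxylic acid.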